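The compounds below may be only part of what the source reports. "The series", "measured", "known", "first", "only" and "open" are said of these compounds alone.

Compound 1 (`COc1ccc(N2CCN(C(=S)SCc3ccc4nc(N)nc(N)c4c3)CC2)cc1`), compound 2 (`Nc1nc(N)c2cc(CSC(=S)N3CCN(c4ccc(Cl)cc4)CC3)ccc2n1`) and compound 3 (`Nc1nc(N)c2cc(CSC(=S)N3CCN(c4ccccc4Cl)CC3)ccc2n1`) share one core and differ only in the substituted phenyl group on an amine nitrogen in a ring. In a functional assay on HT-29 cells (Homo sapiens) for antiproliferative activity, read by MTT assay, with a stated time of 72 h (a lower number here means a stronger inhibitor, a higher number a weaker inhibitor), compound 1 gives 1770 nM, compound 2 gives 7480 nM and compound 3 gives 3900 nM. Compound 1 is the strongest of the three. Compound 3 cannot be told apart from compound 2, given a 1.9-fold lower number from compound 2 to compound 3 (0.28 log units; within the scatter), while the gap to its stronger relative is a 2.2-fold higher number from compound 1 to compound 3 (0.34 log units; beyond the scatter).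

Compound 4 (`Nc1nc(N)c2cc(CSC(=S)N3CCN(c4ccc([N+](=O)[O-])cc4)CC3)ccc2n1`) carries 4-nitrophenyl in place of 2-chlorophenyl on an amine nitrogen in a ring. For the measured compounds named here, no measured compound holds a nitro group, so the evidence is indirect. Swapping the group on this phenyl ring has so far produced only modest steps, with the largest being a 4.2-fold higher number from compound 1 to compound 2 (0.63 log units; beyond the scatter). Going by the values given here, compound 2, the nearest match with its single group in the same place, gives 7480 nM.

On that basis, no step beyond the scatter is expected in this assay, and no direction can be favoured with confidence. The expected step is a 1.0-fold higher number from compound 3 to compound 4 (0.01 log units; within the scatter). For compound 4 the estimate is 4000 nM, with an expected range from 1600 nM to 10000 nM.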

Compound 4, half-maximal inhibitory concentration: 3320 nM
Beside the measured number, compound 4's estimate is 1.2-fold (0.08 log units) above it; measured number inside the range.
By their numbers in this assay, from the lowest: compounds 1, 4, 3 and 2 (each within the scatter of the next, the first and the last beyond it).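

Placing 4-nitrophenyl on this ring nitrogen shows that a group built from nitrogen and oxygen, rather than chlorine or a methoxy group, can sit here without a clear loss or gain in this assay against two of its relatives: a 1.2-fold lower number from compound 3 to compound 4 (0.07 log units; within the scatter) and a 1.9-fold higher number from compound 1 to compound 4 (0.27 log units; within the scatter) are both too small to read as real differences. Against the matching 4-chlorophenyl group the change can be read, since a 2.3-fold lower number from compound 2 to compound 4 (0.35 log units; beyond the scatter) makes nitro the better of these two groups in the same place, though only modestly. Compound 4 therefore cannot be separated from compound 1 or compound 3, even though those two can be told apart, and a 4.2-fold higher number from compound 1 to compound 2 (0.63 log units; beyond the scatter) remains the largest step in the set, so this position has still given only modest changes.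

On these data alone, whether an amine, a carboxylic acid or a longer chain on this phenyl ring would give a larger step remains open, as does how 2-nitrophenyl would compare with 4-nitrophenyl. Nothing available here bears on what lies behind these small steps.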